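A few compounds are considered here, and "the series" means these few. Any claim that something is new, unique, unknown or untested is made for them only; others in the source may bear on it.

Measured so far in a functional assay on LM7 cells (Homo sapiens) for antiproliferative activity, read by MTT assay, with a stated time of 72 h; a lower number here means a stronger inhibitor, a higher number a weaker inhibitor:
compound 1 `Cc1ccc2c(=O)c(CSC(=S)N(C(C)C)C(C)C)coc2c1`: 6300 nM
compound 2 `CCOC(=O)c1cc(=O)c2cc(CSC(=S)N(C)c3ccccc3)ccc2o1`: > 25000 nM

Compound 2 gives only a limit, > 25000 nM, in this assay; it stands at the limit of > 25000 nM in this assay, at which 1 of the 2 values shown sits, and so no number is known for it. Compound 3 `CCOC(=O)c1cc(=O)c2cc(CSC(=S)N3CCCC3)ccc2o1` differs from compound 2 by pyrrolidin-1-yl in place of methyl(phenyl)amino on a thiocarbonyl carbon. Going by the values given here, no measured step is available for a change of this kind, so the expectation rests on where compound 2 stands and on compound 1 at 6300 nM. The step from compound 2 to compound 3 in this assay is expected to be an at least 1.2-fold lower number from compound 2 to compound 3 (0.09 log units; that floor lies within the scatter), that is, a gain not clearly beyond the scatter. For compound 3 the estimate in this assay is 20000 nM, with a range from 6000 nM to 60000 nM.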

Compound 3, half-maximal inhibitory concentration: 18000 nM
Compound 3: the middle estimate sits 1.1-fold (0.05 log units) above what was measured, and the stated range covers the measured number.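

Compound 3, with pyrrolidin-1-yl in place of methyl(phenyl)amino on the thiocarbonyl carbon, gives a measurable number in this assay. Compound 2 stands at > 25000 nM, which is a limit and not a number. The change therefore reads only as an at least 1.3-fold lower number from compound 2 to compound 3 (0.14 log units; that floor lies within the scatter), so a floor is known but not the true size of the step, and that floor shows no gain clearly beyond the scatter.

Still open, as far as these compounds go, is how a piperidin-1-yl or morpholin-4-yl group on the same thiocarbonyl carbon would read in this assay. Also open, from the compounds shown here alone, is whether a carboxylic acid in place of the ethyl ester would shift compound 3.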